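The compounds below may be only part of what the source reports. "The series", "measured", "known", "first", "only" and "open" are said of these compounds alone.

Compound 2 `CC(C)[C@H](NC(=O)COc1cccc2ccccc12)C(=O)N[C@@H](CC(=O)O)C(=O)CSc1nccn1C` reaches only a limit in a functional assay on Jurkat cells (Homo sapiens) for inhibition; a higher number here means a weaker inhibitor, a lower number a stronger inhibitor: compound 2 gives > 200000 nM. Compound 3 `CC(C)[C@H](NC(=O)COc1cccc2ccccc12)C(=O)N[C@@H](CC(=O)O)C(=O)CSc1nc2ccccc2s1` likewise stops at a limit, giving > 200000 nM in this assay. Compound 1 `CC(C)[C@H](NC(=O)COc1cccc2ccccc12)C(=O)N[C@@H](CC(=O)O)C(=O)COc1cc(C(F)(F)F)n(C)n1` gives a number in this assay, 46000 nM. Compound 4 `CC(C)[C@H](NC(=O)COc1cccc2ccccc12)C(=O)N[C@@H](CC(=O)O)C(=O)COc1cc(C(F)(F)F)ncn1` differs from compound 2 by (6-(trifluoromethyl)pyrimidin-4-yl)oxy in place of (1-methyl-1H-imidazol-2-yl)sulfanyl on a saturated chain carbon bound to a carbonyl carbon. The measured step that bears on this is the one running the other way, an at least 4.3-fold higher number from compound 1 to compound 2 (0.63 log units; beyond the scatter), where a (1-methyl-5-(trifluoromethyl)-1H-pyrazol-3-yl)oxy group gave way to the (1-methyl-1H-imidazol-2-yl)sulfanyl group that now leaves; an at least 4.3-fold higher number from compound 1 to compound 3 (0.63 log units; beyond the scatter) points the same way. Returning to an aryloxy group carrying a trifluoromethyl is therefore expected to lower the number by at least a modest step, an at least 3.3-fold lower number from compound 2 to compound 4 (0.52 log units; beyond the scatter). Compound 4 is expected to give 60000 nM, estimated between 20000 nM and 200000 nM.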

Compound 4, half-maximal inhibitory concentration: > 200000 nM
Compound 4: a limit, no number; the forecaster's own chance of this, stated with the estimate: 25%; at least 3.3-fold (0.52 log units) between middle value and limit.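

In this assay compound 4 stops at a limit, > 200000 nM. With the oxygen and the trifluoromethyl both kept, 6-(trifluoromethyl)pyrimidin-4-yl in place of 1-methyl-5-(trifluoromethyl)-1H-pyrazol-3-yl still gives an at least 4.3-fold higher number from compound 1 to compound 4 (0.63 log units; beyond the scatter), so on this carbon an oxygen-linked ring carrying trifluoromethyl does not by itself hold the activity of compound 1, and the ring matters. The steps from compound 2 and compound 3 to compound 4 cannot be read: the limit of > 200000 nM in this assay, at which 3 of the 4 values shown sit.

As far as these compounds go, only compound 1 gives a number, so the size of these ring effects stays open. Also open, from the compounds shown here alone, is whether a nitrile in place of the trifluoromethyl of compound 1 would keep its value.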